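Replacing the Sulfonyl Aryl Group: From Compound 2 to Compound 4

The compounds below may be only part of what the source reports. "The series", "measured", "known", "first", "only" and "open" are said of these compounds alone.

Measured so far in an assay on isolated protein for displacement of a labelled ligand from metabotropic glutamate receptor 5 (Homo sapiens), with a stated time of 60 min, tested at 1 uM; a higher number here means more inhibition at the concentration tested (going by the name of the read-out), a lower number less inhibition:
- compound 1, `Cc1ccc(S(=O)(=O)c2cnc3ccc(F)cc3c2N2CCC(C)CC2)cc1`, gives 91%
- compound 2, `Cc1ccc(S(=O)(=O)c2cnc3ccc(Cl)cc3c2N2CCC(C)CC2)cc1`, gives 95%
- compound 3, `COc1ccc2ncc(S(=O)(=O)c3ccc(C)c(F)c3)c(N3CCC(C)CC3)c2c1`, gives 73%

Compound 2 stands highest of these three numbers. Within the data shown here, compound 1 sits nearest, and the single step between them, a number 4 percentage points higher from compound 1 to compound 2 (within the scatter), lies within the scatter, so the two cannot be ranked. Compound 3 lies furthest from compound 2, beyond the scatter, but it differs from compound 2 in two places at once, so no single step can be read from it.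

Compound 4, `CC1CCN(c2c(S(=O)(=O)c3cccc(Cl)c3)cnc3ccc(Cl)cc23)CC1`, has not yet been measured in this assay. It differs from compound 2 in one place: 3-chlorophenyl in place of 4-methylphenyl on a sulfonyl sulfur. Among the measured compounds shown here, none of the measured steps touches the sulfonyl aryl group; the only measured step concerns a substituent on the shared core. The data therefore give no direct guide to the size or direction of this change, and a wide range is appropriate. Compound 4 is expected to give about 84%, between 62% and 97%. The expected step is a number 11 percentage points lower from compound 2 to compound 4 (beyond the scatter), which may well fall within the scatter.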

Compound 4, a percentage reported as inhibition, at one concentration (the size of the read-out at that concentration, not a potency): 92%
For compound 4 the middle estimate is 8 percentage points below the measured one, and the stated range covers the measured number.
By their numbers in this assay, from the lowest: compound 3; then compounds 1, 4 and 2 (each within the scatter of the next).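

In this assay, the sulfonyl aryl group now has its first single-place step: putting 3-chlorophenyl in place of 4-methylphenyl on a sulfonyl sulfur gives a number 3 percentage points lower from compound 2 to compound 4 (within the scatter), so the two compounds cannot be ranked. The read-out therefore stays level across this exchange of a methyl-bearing ring for a chlorine-bearing ring, at least in this one pair, where the shared core keeps its chloro group. No measured evidence bears on why the read-out holds across this change.

The change alters both the substituent and its ring position, so 3-methylphenyl or 4-chlorophenyl would be needed to separate those two effects. On these data alone, it also remains open whether this position would hold the read-out with a very different group on the ring, such as an amine or a carboxylic acid.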